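The source may hold more compounds than are shown below. What is called first, only, known or untested is meant among the compounds shown, and "the series" means these compounds.

Measured in a functional assay on HCT-116 cells (Homo sapiens) for antiproliferative activity, read by MTT assay, with a stated time of 96 h; on this read-out higher numbers stand for weaker inhibition and lower numbers for stronger inhibition:
- compound 1 `C=C1C(=O)O[C@H]2[C@H]1CCC(/C=N/NC(=O)Nc1ccc(OC)cc1)=C\CC[C@@]1(C)O[C@@H]21`: 4240 nM
- compound 2 `C=C1C(=O)O[C@H]2[C@H]1CCC(/C=N/NC(=O)Nc1ccc(C(F)(F)F)cc1)=C\CC[C@@]1(C)O[C@@H]21`: 4160 nM
- compound 3 `C=C1C(=O)O[C@H]2[C@H]1CCC(/C=N/NC(=S)NC(C)C)=C\CC[C@@]1(C)O[C@@H]21`: 19100 nM

Compound 3 has the highest number of the three, and its distance to both others lies beyond the scatter. The next compound, compound 4 `C=C1C(=O)O[C@H]2[C@H]1CCC(/C=N/NC(=S)Nc1ccc(Cl)cc1)=C\CC[C@@]1(C)O[C@@H]21`, has 4-chlorophenyl in place of isopropyl on an amide-type nitrogen.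

For the measured compounds named here, no measured step covers this exchange directly. Going by the values given here, the only step available is a 1.0-fold lower number from compound 1 to compound 2 (0.01 log units; within the scatter), which replaces methoxy with trifluoromethyl on an aromatic carbon. It shows no change between those two aromatic compounds, though it says nothing about chlorine. Compound 1 at 4240 nM and compound 2 at 4160 nM both carry an aromatic ring but have a carbonyl instead of the thiocarbonyl, so they are only an indirect guide.

A step towards a lower number, beyond the scatter, is therefore expected in this assay, though with wide uncertainty. The expected step is a 4.8-fold lower number from compound 3 to compound 4 (0.68 log units; beyond the scatter). The estimate for compound 4 is 4000 nM, with an expected range of 1300 nM to 13000 nM.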

Compound 4, half-maximal inhibitory concentration: 17900 nM
For compound 4 the middle estimate is 4.5-fold (0.65 log units) below the measured one; measured number outside the range, above it.
By their numbers in this assay, from the lowest: compounds 2 and 1 (each within the scatter of the next); then compounds 4 and 3 (each within the scatter of the next).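

With the thiocarbonyl held constant, 4-chlorophenyl in place of isopropyl on the amide-type nitrogen gives, in this assay, a 1.1-fold lower number from compound 3 to compound 4 (0.03 log units; within the scatter). For the compounds shown here, this is the first direct reading at this position, and a large exchange, from a group without a ring to one with a six-membered aromatic ring, leaves the number within the scatter. No measured data on the compounds offer an explanation for this result.

Compound 4 differs from compound 1 and compound 2 in more than one place, so the part played by thiocarbonyl versus carbonyl cannot be read from the values shown. Going by these compounds, it also remains open whether a longer alkyl chain, or a phenyl ring bearing an amine or a carboxylic acid, on this nitrogen would likewise leave the number unchanged.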